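Swapping the methylsulfonyl for a tetrazole in compound 4

The compounds below may be only part of what the source reports. "The series", "measured", "known", "first", "only" and "open" are said of these compounds alone.

Of the compounds shown here, three sharing one core have been measured in a functional assay on CHO cells for agonist activity at Glucose-dependent insulinotropic receptor (Homo sapiens), read by cAMP accumulation; on this read-out lower numbers stand for an effect already at smaller amounts and higher numbers for an effect only at larger amounts of compound. Compound 1 `CCOc1cnc(N2CCC([C@H]3C[C@H]3COCc3ccc(S(C)(=O)=O)c(F)c3)CC2)nc1` gives 1.7 nM, compound 3 `CS(=O)(=O)c1ccc(COC[C@@H]2C[C@@H]2C2CCN(c3ncc(F)cn3)CC2)cc1F` gives 2.4 nM, and compound 2 `COCc1cnc(N2CCC([C@H]3C[C@H]3COCc3ccc(S(C)(=O)=O)c(F)c3)CC2)nc1` gives 3.3 nM, the highest of the three numbers, though every gap among them lies within the scatter: a 1.9-fold higher number from compound 1 to compound 2 (0.29 log units; within the scatter), a 1.4-fold higher number from compound 1 to compound 3 (0.15 log units; within the scatter), a 1.4-fold lower number from compound 2 to compound 3 (0.14 log units; within the scatter). Compound 4 `COCc1cnc(N2CCC([C@H]3C[C@H]3COCc3ccc(-n4cnnn4)c(F)c3)CC2)nc1` has not been measured; it differs from compound 2 by 1H-tetrazol-1-yl in place of methylsulfonyl on an aromatic carbon. All three measured steps change only the group on the other aromatic ring, so none bears on this exchange, and no guidance on its size exists in these data. Compound 4 is therefore estimated at 8 nM, with a range from 2 nM to 40 nM, meaning an expected step of a 2.4-fold higher number from compound 2 to compound 4 (0.38 log units; beyond the scatter).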

Compound 4, half-maximal effective concentration: 1.1 nM
The estimate for compound 4 lay 7.3-fold (0.86 log units) above the measured number, outside the stated range (below it).
By their numbers in this assay, from the lowest: compounds 4, 1, 3 and 2 (each within the scatter of the next, the first and the last beyond it).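

For the compounds shown here, the earlier compounds varied only the group on the other aromatic ring, so this is the first look at the position ortho to a fluoro group and para to a large group. Putting 1H-tetrazol-1-yl in place of methylsulfonyl brings a 3.0-fold lower number from compound 2 to compound 4 (0.48 log units; beyond the scatter) and shows that the sulfur group is not needed here for a low number. Nothing shown gives a reason for this step. As far as these compounds go, whether a carboxylic acid or an amine would work on this carbon stays open, as does whether 1H-tetrazol-1-yl gives a similar step with the ethoxy or fluoro groups of compound 1 and compound 3.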